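Cyano for fluoro: an expected flat step

The compounds below may be only part of what the source reports. "The series", "measured", "known", "first", "only" and "open" are said of these compounds alone.

Measured in a functional assay on DLD-1 cells (Homo sapiens) for cytotoxicity, with a stated time of 48 h; a lower number here means a stronger inhibitor, a higher number a weaker inhibitor:
- compound 1 `CCCCCOc1ccc2oc(/C=C/[S+](C)[O-])cc(=O)c2c1` gives 6600 nM
- compound 2 `C[S+]([O-])/C=C/c1cc(=O)c2cc(F)ccc2o1` gives 7000 nM

Going by the values given here, on these numbers, compound 2 cannot be told apart from compound 1, the only other compound measured. The next compound is compound 3 `C[S+]([O-])/C=C/c1cc(=O)c2cc(C#N)ccc2o1`, which differs from compound 2 by one change: cyano in place of fluoro on an aromatic carbon. In words, this is cyano in place of fluoro on an aromatic carbon.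

Among the compounds with values here, only one measured step bears on this. It is a 1.1-fold higher number from compound 1 to compound 2 (0.03 log units; within the scatter), with fluoro in place of pentyloxy on an aromatic carbon, and it lies within the scatter. That swap of two quite different groups left the number in this assay unresolved, so no clear direction can be drawn from it. Cyano itself has not been measured in this series, and a single step is thin support, so the range is kept wide. The expected step is a 1.1-fold lower number from compound 2 to compound 3 (0.03 log units; within the scatter), which means no change beyond the scatter is expected. For compound 3 the estimated value is 6500 nM, with an expected range from 2800 nM to 15000 nM.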

Compound 3, half-maximal inhibitory concentration: > 10000 nM
Compound 3: only a limit was reported; the forecaster's own chance of this, stated with the estimate: 5%; middle value at least 1.5-fold (0.18 log units) from the limit.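

In this assay, compound 3 carries only a limit, > 10000 nM, and not a number. Read against that limit, the steps are an at least 1.4-fold higher number from compound 2 to compound 3 (0.15 log units; that floor lies within the scatter) and an at least 1.5-fold higher number from compound 1 to compound 3 (0.18 log units; that floor lies within the scatter); neither floor goes beyond the scatter, so a real loss is not established, but cyano on this aromatic carbon shows no gain over fluoro or pentyloxy, and the earlier pair alone could not say this of a third group. This is also the first result at this position with no upper end, so the flat picture left by fluoro and pentyloxy no longer covers every group placed here, and the whole reading rests on a single entry: the limit of > 10000 nM in this assay, at which 1 of the 3 values shown sits.

As far as these compounds go, how far compound 3 really lies from compound 1 and compound 2 stays open, since only a floor is available for either step. Also open, from the compounds shown here alone, is whether an amine, a carboxylic acid or a longer alkoxy chain on this same carbon would give a value that separates from the others beyond the scatter, and whether any such group would give a lower number than fluoro does.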